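Swapping a Thiazole for a Carboxypyridine on the Shared Core

The source may hold more compounds than are shown below. What is called first, only, known or untested is meant among the compounds shown, and "the series" means these compounds.

Of the compounds shown here, three built on a shared core have been measured in a functional assay on HEK293 cells for agonist activity at Bombesin receptor subtype-3 (Mus musculus), read by luminescence and calcium flux, with a stated time of 10 min; a higher number here means that more compound is needed for the effect, a lower number that less compound is needed. Compound 1 `CCC(C)(C)Cc1c[nH]c(CCc2ccc(-n3ncnn3)cc2)n1` gives 25 nM, compound 2 `CCC(C)(C)Cc1c[nH]c(CCc2ccc(N3CCCCC3)cc2)n1` gives 28 nM, and compound 3 `CCC(C)(C)Cc1c[nH]c(CCc2ccc(-c3cnsc3)cc2)n1` gives 6.9 nM, the lowest number of the three. The steps of a 3.6-fold lower number from compound 1 to compound 3 (0.56 log units; beyond the scatter) and a 4.1-fold lower number from compound 2 to compound 3 (0.61 log units; beyond the scatter) both show a modest gain on arriving at the 1,2-thiazol-4-yl, whereas a 1.1-fold higher number from compound 1 to compound 2 (0.05 log units; within the scatter) lies within the scatter. Compound 4 `CCC(C)(C)Cc1c[nH]c(CCc2ccc(-c3cccnc3C(=O)O)cc2)n1` differs from compound 3 by 2-carboxypyridin-3-yl in place of 1,2-thiazol-4-yl on an aromatic carbon. Within the data shown here, no measured step covers the entering group, so the expectation rests only on the fact that the group now leaving was the one whose arrival brought the gain, which is likely to be given back. Compound 4 is therefore expected to give 30 nM, within 8 nM to 120 nM. This corresponds to an expected step of a 4.3-fold higher number from compound 3 to compound 4 (0.64 log units; beyond the scatter).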

Compound 4, half-maximal effective concentration: 14 nM
For compound 4 the middle estimate is 2.1-fold (0.33 log units) above the measured one; the measured number falls inside the stated range.
By their numbers in this assay, from the lowest: compound 3; then compounds 4, 1 and 2 (each within the scatter of the next).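

In this assay, the position para to a large group tolerates the larger 2-carboxypyridin-3-yl, which carries a hydrogen-bond donor that 1,2-thiazol-4-yl lacks, at a modest cost: a 2.0-fold higher number from compound 3 to compound 4 (0.31 log units; beyond the scatter). The other two comparisons stay within the scatter, with a 2.0-fold lower number from compound 2 to compound 4 (0.30 log units; within the scatter) and a 1.8-fold lower number from compound 1 to compound 4 (0.25 log units; within the scatter). Compound 3 therefore keeps the lowest number, beyond the scatter of all three others.

Nothing here bears on what lies behind these steps. From the compounds shown here alone, whether the pyridine ring or the carboxylic acid sets the value stays open, and a plain pyridine or the methyl ester would help to separate them.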